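A few compounds are considered here, and "the series" means these few. Any claim that something is new, unique, unknown or untested is made for them only; others in the source may bear on it.

Working notes on the series. In an ADME assay on S9 fraction from liver (Rattus norvegicus) for metabolic stability, read by LC-MS, using NADPH, with a stated time of 30 min (a higher number here means that more of the compound is left, a lower number that less of the compound is left), compound 1 (`CCCCCCCCc1ccc(OCC(=O)Cn2nnc(C)n2)cc1`) gives < 5% as a limit, not a number. In this assay compound 2 (`CCCCCCCCc1ccc(OCC(=O)Cn2nnc(SC)n2)cc1`) gives < 5% as a limit too. Among the measured compounds shown here, compound 2 therefore has no exact value, and the only other value is also a limit. For the measured compounds named here, the one measured step is a step that the two limits leave unreadable from compound 1 to compound 2, which has no readable size and shows no direction. Compound 3 (`CCCCCCCCc1ccc(OCC(=O)Cn2nnc(-c3ccccc3)n2)cc1`) has phenyl in place of methylsulfanyl on an aromatic carbon, between two ring nitrogen atoms: phenyl in place of methylsulfanyl on an aromatic carbon. The expectation rests on the limit of < 5% in this assay, at which 2 of the 2 values shown sit, and on compound 2, whose limit leaves little room for a further fall. No rise is supported by the data either, so no change beyond the scatter is expected. The expected change is a step that the limit leaves unreadable from compound 2 to compound 3 in this reading. For compound 3 the estimated value is 4%, with an expected range from 1% to 12% in this assay.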

Compound 3, percent of the compound remaining: 33%
For compound 3 the middle estimate is 29 percentage points below the measured one; the measured number lies above the stated range.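

In this assay, phenyl on this aromatic carbon, between two ring nitrogen atoms, gives a number at least 28 percentage points higher from compound 2 to compound 3 (beyond the scatter) where methylsulfanyl stood. Against methyl at the same place, the change gives a number at least 28 percentage points higher from compound 1 to compound 3 (beyond the scatter). With the rest of the core unchanged, the group at this one position can therefore lift the read-out clear of the limit, and of the three groups shown only phenyl gives a readable number; the steps between the other groups cannot be read: the limit of < 5% in this assay, at which 2 of the 3 values shown sit.

The compounds shown leave open whether the rise goes with the six-membered aromatic ring itself or simply with the larger count of heavy atoms. Going by these compounds, a cyclohexyl group or a benzyl group on the same carbon would separate these two readings, and the rest of the core remains untested by these three compounds.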